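This account rests on a few compounds, and the source may have more. Where it says the series, first, only, none or still open, it means among the compounds named here.

Measured so far:
- compound 1 `Cc1ccc(CNC(=O)c2nn(-c3ccc(F)cc3)c(OC[C@@H](O)C[C@@H](O)CC(=O)O)c2C(C)C)cc1`: 15 nM
- compound 2 `CC(C)c1c(C(=O)NCc2ccccn2)nn(-c2ccc(F)cc2)c1OC[C@@H](O)C[C@@H](O)CC(=O)O`: 25 nM

Both were tested in an assay on microsomes from liver for inhibition of 3-hydroxy-3-methylglutaryl-coenzyme A reductase (Rattus norvegicus); on this read-out lower numbers stand for stronger inhibition and higher numbers for weaker inhibition. Compound 1 gives the lowest of the two numbers, but its nearest neighbour, compound 2, differs only by a 1.7-fold higher number from compound 1 to compound 2 (0.22 log units; within the scatter), so the two cannot be ordered against each other.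

Compound 3 `Cc1cccc(CN(C)C(=O)c2nn(-c3ccc(F)cc3)c(OC[C@@H](O)C[C@@H](O)CC(=O)O)c2C(C)C)c1` has not yet been measured. Compared with compound 1 it carries the change (methyl(3-methylbenzyl)amino in place of (4-methylbenzyl)amino on a carbonyl carbon). This is a change at the amide part of the shared core, the part that compound 1 and compound 2 also vary between them.

Among the measured compounds shown here, only one measured step bears on it: a 1.7-fold higher number from compound 1 to compound 2 (0.22 log units; within the scatter), which shows that swapping the aromatic group on that chain carbon hardly moves the number. For the measured compounds named here, no measured step covers the replacement of the amide hydrogen by a methyl group, so that part of the change has no precedent here. Taking the single step as the best guide, and allowing for the uncharted part, the expected step in this assay is a modest one, if any, toward a higher number: a 2.3-fold higher number from compound 1 to compound 3 (0.37 log units; beyond the scatter). Compound 3 is therefore estimated at 35 nM, within 8 nM to 150 nM.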

Compound 3, half-maximal inhibitory concentration: 37 nM
Compound 3: the middle estimate sits 1.1-fold (0.02 log units) below what was measured; low and high end bracket the measured number.
By their numbers in this assay, from the lowest: compounds 1, 2 and 3 (each within the scatter of the next, the first and the last beyond it).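

Among the compounds shown here, this is the first step at this place on the carbonyl carbon that lies beyond the scatter: in this assay the exchange of (4-methylbenzyl)amino for methyl(3-methylbenzyl)amino gives a 2.5-fold higher number from compound 1 to compound 3 (0.39 log units; beyond the scatter), a modest loss for a group that has 0 hydrogen-bond donors where the group it replaces has 1. The same place carrying ((pyridin-2-yl)methyl)amino gives a different picture, with a 1.5-fold higher number from compound 2 to compound 3 (0.17 log units; within the scatter), so these two compounds cannot be ordered against each other and only the comparison with the 4-methylbenzyl amide shows a real difference. Nothing given here explains why the number moves.

As far as these compounds go, two things change at once in this step, a methyl group takes the place of the amide hydrogen and the ring methyl goes from the 4-methylbenzyl to the 3-methylbenzyl arrangement, so the share of each stays unknown; (3-methylbenzyl)amino or methyl(4-methylbenzyl)amino would separate them. From the compounds shown here alone, how far this place reaches also stays open, for instance with a longer chain such as (2-phenylethyl)amino, or with a plain unsubstituted benzylamino group.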